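Nitro for methyl on the aryl group: working notes

The source may report more compounds than this note shows. Statements on the series, on what has been measured and on what is new or still open speak of the compounds shown alone.

- compound 1 `Cc1c(NC(=O)NCCN2C(=O)S/C(=C\c3ccc([N+](=O)[O-])cc3)C2=O)c(=O)n(-c2ccccc2)n1C` gives 18600 nM
- compound 2 `Cc1ccc(/C=C2\SC(=O)N(CC(=O)Nc3c(C)n(C)n(-c4ccccc4)c3=O)C2=O)cc1` gives 65500 nM

In a functional assay on MCF7 cells (Homo sapiens) for inhibition, read by MTT assay, with a stated time of 48 h (a lower number here means a stronger inhibitor, a higher number a weaker inhibitor), compound 2 holds the higher of the two numbers at 65500 nM and is the weaker inhibitor of the pair. Its gap to compound 1 lies beyond the scatter.

Next in the series is compound 3 `Cc1c(NC(=O)CN2C(=O)S/C(=C\c3ccc([N+](=O)[O-])cc3)C2=O)c(=O)n(-c2ccccc2)n1C`, which differs from compound 2 in one place (nitro in place of methyl on an aromatic carbon), with nitro in place of methyl on an aromatic carbon, para to a large group. The same difference reads 4-methylphenyl to 4-nitrophenyl.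

Going by the values given here, no two measured compounds differ in one place only, so the size of this change in this assay has no direct measure. Among the compounds with values here, the only guide is compound 1, which also carries 4-nitrophenyl and gives 18600 nM as its reading. On that basis a modest step towards a lower number is expected, though a step within the scatter would be no surprise. The estimated move is a 2.2-fold lower number from compound 2 to compound 3 (0.34 log units; beyond the scatter) in this series.

For compound 3 the estimated value is 30000 nM with 12000 nM to 70000 nM as the expected range.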

Compound 3, half-maximal inhibitory concentration: 82400 nM
For compound 3 the middle estimate is 2.7-fold (0.44 log units) below the measured one, outside the stated range (above it).
By their numbers in this assay, from the lowest: compound 1; then compounds 2 and 3 (each within the scatter of the next).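

In this assay, the direct reading of this change is a 1.3-fold higher number from compound 2 to compound 3 (0.10 log units; within the scatter), so on this aromatic carbon, para to a large group, the 4-methylphenyl and 4-nitrophenyl groups are not separated, although nitro brings hydrogen-bond acceptors and methyl brings none. Going by these compounds alone, compound 1 also carries 4-nitrophenyl and gives 18600 nM, but no step in one place links it to compound 2 or compound 3, so its reading can no longer be taken as a measure of this change, and whatever sets it apart remains unassigned. No measurement at hand accounts for the result at this position.

The shown compounds span only methyl and nitro at this place, so it remains open whether an amine, a carboxylic acid or a halogen such as chlorine would also leave the number within the scatter in this assay. Also open, from the compounds shown here alone, is whether the methyl-to-nitro exchange would read the same on the longer urea-bearing chain of compound 1, which would need the 4-methylphenyl partner of that compound.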